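Adding a methoxy group to the pendant phenyl ring

This account rests on a few compounds, and the source may have more. Where it says the series, first, only, none or still open, it means among the compounds named here.

Three compounds sharing the core of compound 1 `Cc1ccc(N2C(=O)COc3ccc(-c4cnc5ccccc5c4)cc32)cc1` have been tested in a functional assay on HeLa cells (Homo sapiens) for antiproliferative activity, read by MTT assay, with a stated time of 72 h; a higher number here means a weaker inhibitor, a lower number a stronger inhibitor. Compound 1 gives only a limit of the assay, > 40000 nM. Compound 3 `O=C1COc2ccc(-c3cnc4ccccc4c3)cc2N1c1ccccc1` likewise gives only a limit, > 40000 nM. Among the measured compounds shown here, the single step between them, a step that the two limits leave unreadable from compound 1 to compound 3, cannot be read because both values sit at the limit of > 40000 nM in this assay, at which 2 of the 3 values shown sit. For the measured compounds named here, compound 2 `O=C1COc2ccc(-c3cnc(Cl)c(NS(=O)(=O)c4ccc(F)cc4)c3)cc2N1c1ccccc1` gives 10300 nM in this assay; it differs from compound 3 in more than one place, so no single step joins the two.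

Compound 4 `COc1cccc(N2C(=O)COc3ccc(-c4cnc5ccccc5c4)cc32)c1` has not yet been measured in this assay. It differs from compound 3 by methoxy in place of hydrogen on an aromatic carbon, placed on an aromatic carbon of a six-membered aromatic ring of carbon only. Going by the values given here, no measured step bears directly on this change, since the only one-place step available is unreadable. With compound 3 standing at a limit, the expected step that the limit leaves unreadable from compound 3 to compound 4 is estimated to bring no change beyond the scatter. Compound 4 is therefore expected to give about 45000 nM, within a range from 15000 nM to 150000 nM, most likely again as a limit.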

Compound 4, half-maximal inhibitory concentration: 11400 nM
Beside the measured number, compound 4's estimate is 3.9-fold (0.60 log units) above it; the whole stated range lies above it.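

In this assay, among the compounds shown here, the pendant phenyl ring now gives a readable change for the first time, since the one earlier step on this ring could not be read: methoxy on this ring brings an at least 3.5-fold lower number from compound 3 to compound 4 (0.54 log units; beyond the scatter). The comparison with the 4-methylphenyl compound points the same way, as exchanging that group for 3-methoxyphenyl gives an at least 3.5-fold lower number from compound 1 to compound 4 (0.54 log units; beyond the scatter). Both sizes are only lower bounds, because each starting compound stands at a limit rather than at a true number: the limit of > 40000 nM in this assay, at which 2 of the 4 values shown sit.

A single compound cannot show whether methoxy would give a similar change at another place on this ring, or how large the true step is. Going by these compounds, it also remains open whether an amine, a carboxylic acid or a longer chain such as ethoxy at this position would lower the number as well.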